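Removing a phenyl ring: effect on cell tolerance

The compounds below may be only part of what the source reports. "The series", "measured", "known", "first", "only" and "open" are said of these compounds alone.

Four compounds share a piperidine amide built around a fused two-ring core that carries a methoxybenzyl group. Compound 1 `CCCNC(=O)C1CCN(C(=O)c2cc3scnc3n2Cc2ccc(OC)cc2)CC1` and compound 2 `CCCNC(=O)C1CCN(C(=O)c2cc3sc(-c4ccccc4)nc3n2Cc2ccc(OC)cc2)CC1` were tested in an ADME assay on HEK-293T cells (Homo sapiens) for cytotoxicity, read by luminescence and CellTiter-Glo, with a stated time of 24 h; a higher number here means that more compound is tolerated, a lower number that less compound is tolerated. Compound 1 gives 19100 nM, and compound 2 gives 22900 nM. The change between them is hydrogen in place of phenyl on an aromatic carbon, and the resulting step, a 1.2-fold lower number from compound 2 to compound 1 (0.08 log units; within the scatter), is small. Compound 3 `CCCNC(=O)C1CCN(C(=O)c2cc3sc(-c4ccccc4)cc3n2Cc2ccc(OC)cc2)CC1` has a different core; how the two cores differ is not broken down here. In this assay compound 3 reaches only a limit of the assay, > 100000 nM, rather than a number. Compound 4 `CCCNC(=O)C1CCN(C(=O)c2cc3sccc3n2Cc2ccc(OC)cc2)CC1` has not yet been measured. It arises from compound 3 by hydrogen in place of phenyl on an aromatic carbon, the same kind of change as that from compound 2 to compound 1, but not the same, since here the five-membered ring holds only sulfur and the carbon lies next to the ring sulfur. In this assay the expected step is a step that the limit leaves unreadable from compound 3 to compound 4, resting on the small step of a 1.2-fold lower number from compound 2 to compound 1 (0.08 log units; within the scatter) and on compound 3 sitting at the limit of > 100000 nM in this assay, at which 1 of the 3 values shown sits. Compound 4 is therefore expected to give about 120000 nM, between 50000 nM and 300000 nM.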

Compound 4, half-maximal cytotoxic concentration: 18800 nM
Beside the measured number, compound 4's estimate is 6.4-fold (0.81 log units) above it, and the stated range ends above it.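

In this assay, putting hydrogen in place of phenyl gives an at least 5.3-fold lower number from compound 3 to compound 4 (0.72 log units; beyond the scatter), so this change does not carry over unchanged from one core to the other: the same change on two cores in this assay, a 1.2-fold lower number (0.08 log units; within the scatter) from compound 2 to compound 1 and an at least 5.3-fold lower number (0.72 log units; beyond the scatter) from compound 3 to compound 4, at least 4.4-fold (0.64 log units) apart, beyond the scatter of two such steps. Compound 3 sits at a limit of the assay, > 100000 nM, so only a minimum size is known for its step: the limit of > 100000 nM in this assay, at which 1 of the 4 values shown sits. These two pairs show that the same swap can give different results on different cores, but they do not show which feature of the cores matters, and two pairs make no general rule for the series.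

The compounds shown leave open whether a group other than phenyl on this aromatic carbon, such as a methyl group, a chlorine atom or an amine, would behave as phenyl does on each core. As far as these compounds go, it also remains open whether the gap between the two cores would persist with a longer chain in place of the propyl group.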